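Sulfur gives way to oxygen in compound 3

The source may hold more compounds than are shown below. What is called first, only, known or untested is meant among the compounds shown, and "the series" means these compounds.

In a functional assay on A2780 cells (Homo sapiens) for inhibition, read by sulforhodamine B assay, with a stated time of 72 h (a higher number here means a weaker inhibitor, a lower number a stronger inhibitor), compound 1 `O=C(NCc1ccc(S(=O)(=O)c2ccccc2)cc1)c1nc2ccncc2s1` gives > 10000 nM as a limit of the assay. Within the data shown here, compound 2 `O=C(NCc1ccc(S(=O)(=O)N2CCCCC2)cc1)c1cc2cnccc2s1` gives 1600 nM there, the only actual number so far. Compound 3 `O=C(NCc1ccc(S(=O)(=O)N2CCCCC2)cc1)c1cc2cnccc2o1` differs from compound 2 only in the group on the carbonyl carbon: a group of 9 heavy atoms (7 carbon, 1 nitrogen, 1 oxygen; one five-membered aromatic ring with 1 hetero atom, one six-membered aromatic ring with 1 hetero atom) in place of a group of 9 heavy atoms (7 carbon, 1 nitrogen, 1 sulfur; one five-membered aromatic ring with 1 hetero atom, one six-membered aromatic ring with 1 hetero atom), on a carbonyl carbon is the whole change, with oxygen entering where sulfur leaves. Among the measured compounds shown here, no measured step bears on this swap, and only a small shift toward weaker inhibition is expected, close to the usual scatter. The estimated move a 1.4-fold higher number from compound 2 to compound 3 (0.14 log units; within the scatter) stays modest. In this assay compound 3 is expected at 2200 nM with an estimated range from 800 nM to 6500 nM for its half-maximal inhibitory concentration.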

Compound 3, half-maximal inhibitory concentration: 1500 nM
The estimate for compound 3 lay 1.5-fold (0.17 log units) above the measured number, and the stated range covers the measured number.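

In this assay, oxygen entering where sulfur leaves, on a carbonyl carbon, gives a 1.1-fold lower number from compound 2 to compound 3 (0.03 log units; within the scatter). Among these compounds, this is the first step read at this place, and it shows that this one swap leaves the number within the scatter. The data give no cause for this.

Going by these compounds, whether an open chain such as a butyl group on the same carbonyl carbon would shift the number stays open. Compound 1 is held only as a limit of the assay, so it gives no number to read against the others: the limit of > 10000 nM in this assay, at which 1 of the 3 values shown sits.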